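Methoxy Added to the Chlorobenzyl Arm of Compound 1

The source may hold more compounds than are shown below. What is called first, only, known or untested is meant among the compounds shown, and "the series" means these compounds.

Measured compounds:
compound 1 `OC[C@@]1(O)CO[C@@H](n2cnc3c(NCc4cccc(Cl)c4)ncnc32)[C@@H]1O` — 10%
compound 2 `OC[C@]1(O)CO[C@@H](n2cnc3c(NCc4cccc(Cl)c4)ncnc32)[C@@H]1O` — 19%
compound 3 `Nc1ncnc2c1ncn2[C@@H]1OC[C@](O)(CO)[C@H]1O` — 6%

In an assay on CHO cells for displacement of a labelled ligand from adenosine receptor A1 (Homo sapiens), tested at 10 uM (a lower number here means less inhibition, a higher number more inhibition at the concentration tested (going by the name of the read-out)), compound 1 gives 10%. Within the three numbers this is the second highest; the nearest is compound 3 at 6%, and compound 2 stands at 19%. Both neighbouring steps stay within the scatter: a number 9 percentage points higher from compound 1 to compound 2 (within the scatter), which rests on (the fact that compounds 1 and 2 differ only in the configuration as drawn), and a number 4 percentage points lower from compound 1 to compound 3 (within the scatter), where hydrogen replaces the 3-chlorobenzyl group on the ring nitrogen. Neither step therefore marks a change in this assay that can be trusted.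

Compound 4 `COc1ccc(Cl)cc1CNc1ncnc2c1ncn2[C@@H]1OC[C@](O)(CO)[C@H]1O` keeps the core of compound 1 and adds a methoxy group: methoxy in place of hydrogen on an aromatic carbon. Read one bond further out, the change is 3-chlorophenyl to 5-chloro-2-methoxyphenyl. No measured step involves a methoxy group, so none of the shown steps bears directly on this change; the steps that do exist around compound 1 are all within the scatter, and the benzyl arm itself can be removed without a step beyond the scatter. On that basis compound 4 is expected to show a step of a number 2 percentage points higher from compound 1 to compound 4 (within the scatter) in this assay, which is no change beyond the scatter. Compound 4 is therefore estimated at 12%, with a range from 0% to 28%.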

Compound 4, a percentage reported as inhibition, at one concentration (the size of the read-out at that concentration, not a potency): 12%
For compound 4 middle estimate and measured number coincide at the digits printed; measured number inside the range.
By their numbers in this assay, from the lowest: compounds 3, 1, 4 and 2 (each within the scatter of the next, the first and the last beyond it).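

Methoxy in place of hydrogen on an aromatic carbon, ortho to a large group and para to a chloro group, gives in this assay a number 2 percentage points higher from compound 1 to compound 4 (within the scatter). For the compounds shown here, this is the first reading of a substituent added to the aromatic ring of the benzyl arm, since the earlier steps covered only a change of configuration and the loss of the whole 3-chlorobenzyl group, and at this position methoxy produces no change that can be trusted in this assay. Nothing measured here accounts for the size of this step.

The compounds shown leave open whether an amine, a carboxylic acid or a longer chain such as ethoxy or butoxy at this same position would move the number beyond the scatter, or whether any group here does so only in combination with another change to the arm. They also leave open whether methoxy at this position would read the same on the configuration drawn in compound 2, the other stereoisomer of compound 1.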